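Oxazole-piperazine amides: aryl swap on the piperazine nitrogen

A few compounds are considered here, and "the series" means these few. Any claim that something is new, unique, unknown or untested is made for them only; others in the source may bear on it.

Measured so far:
compound 1 `Cc1nc(-c2ccccc2)c(C(=O)N2CCN(c3cccc(C(N)=O)c3)CC2)o1` — 71 nM
compound 2 `Cc1nc(-c2ccccc2)c(C(=O)N2CCN(c3cc(Cl)cc(Cl)c3)CC2)o1` — 41.8 nM

In a functional assay on HL-60 cells (Homo sapiens) for inhibition, read by MTT assay, with a stated time of 72 h (on this read-out higher numbers stand for weaker inhibition and lower numbers for stronger inhibition), compound 1 gives 71 nM and compound 2 gives 41.8 nM. Within the data shown here, the one step so far, a 1.7-fold lower number from compound 1 to compound 2 (0.23 log units; within the scatter), separates the two, so their numbers sit within the scatter of each other and compound 2 cannot be set apart from compound 1 on this read-out.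

Compound 3 `CC(=O)Nc1cccc(N2CCN(C(=O)c3oc(C)nc3-c3ccccc3)CC2)c1` is not yet measured. It differs from compound 2 as follows: 3-acetamidophenyl in place of 3,5-dichlorophenyl on an amine nitrogen in a ring. Among the measured compounds shown here, the only step that bears on this change is a 1.7-fold lower number from compound 1 to compound 2 (0.23 log units; within the scatter), in which a group with one hydrogen-bond donor and one acceptor on that ring nitrogen was replaced by the dichlorophenyl without a change beyond the scatter. The 3-acetamidophenyl entering in compound 3 again brings one donor and one acceptor, so the move is closer in kind to a return toward compound 1 than to anything new. No step beyond the scatter is therefore expected in this assay.

The number for compound 3 is expected at 65 nM, within 25 nM to 170 nM, which means an expected step of a 1.6-fold higher number from compound 2 to compound 3 (0.19 log units; within the scatter), in the direction of compound 1.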

Compound 3, half-maximal inhibitory concentration: 329 nM
Compound 3: middle estimate off by 5.1-fold (0.70 log units), on the low side; the measured number lies above the stated range.
By their numbers in this assay, from the lowest: compounds 2 and 1 (each within the scatter of the next); then compound 3.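

In this assay, the aryl group on the ring nitrogen can move the number beyond the scatter: 3-acetamidophenyl in place of 3,5-dichlorophenyl gives a 7.9-fold higher number from compound 2 to compound 3 (0.90 log units; beyond the scatter), whereas the earlier step between the other two compounds stayed within it. An amide-bearing aryl group does not by itself account for this, as compound 1 carries carbamoyl and stands within the scatter of compound 2, while acetamido in place of carbamoyl on an aromatic carbon gives a 4.6-fold higher number from compound 1 to compound 3 (0.67 log units; beyond the scatter). The series therefore separates two closely named groups on the same aromatic carbon, but no measurement at hand explains that separation.

As far as these compounds go, it remains open whether the higher number belongs to acetamido specifically or extends to other groups on that aromatic carbon, such as an amine, a carboxylic acid or a longer acylamino chain like propionamido. From the compounds shown here alone, it also remains open whether the same order of these three aryl groups would hold with a group other than phenyl on the shared core.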